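Chloro to fluoro on the phenoxy ring of compound 1

A few compounds are considered here, and "the series" means these few. Any claim that something is new, unique, unknown or untested is made for them only; others in the source may bear on it.

Measured compounds:
compound 1, `COc1ccccc1N1CCN(C[C@H](O)COc2ccc(Cl)cc2)CC1`, 48.8%
compound 2, `COc1ccccc1N1CCN(C[C@@H](O)COc2ccc(Cl)cc2)CC1`, 47.4%
compound 3, `O[C@H](COc1ccc(Cl)cc1)CN1CCN(c2ccccc2F)CC1`, 35.9%

In an assay on HEK293 cells for inhibition of Voltage-dependent T-type calcium channel subunit alpha-1G (Homo sapiens), read by patch clamp, tested at 10 uM (on this read-out lower numbers stand for less inhibition and higher numbers for more inhibition at the one concentration tested (going by the name of the read-out)), compound 1 gives the highest of the three numbers. Compound 2 sits nearest, at a number 1.4 percentage points lower from compound 1 to compound 2 (within the scatter); this rests on (the fact that compounds 1 and 2 differ only in the configuration as drawn). Compound 3 stands furthest, at a number 12.9 percentage points lower from compound 1 to compound 3 (beyond the scatter), a change at the other aromatic ring.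

The next compound, compound 4, is `COc1ccccc1N1CCN(C[C@H](O)COc2ccc(F)cc2)CC1`. It differs from compound 1 by fluoro in place of chloro on an aromatic carbon.

Neither measured step covers this change. The stereo step between compound 1 and compound 2 concerns a different part of the molecule, and the modest drop to compound 3 concerns a different ring and a different pair of groups. For the measured compounds named here, with no direct precedent, a step of small size is expected from compound 1 to compound 4, more likely downward than upward, and possibly within the scatter.

For compound 4 the expected value in this assay is 41%, with a range from 26% to 55%. The expected step is a number 7.8 percentage points lower from compound 1 to compound 4 (within the scatter).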

Compound 4, a percentage reported as inhibition, at one concentration (the size of the read-out at that concentration, not a potency): 41%
Compound 4: the middle estimate sits on the measured number at the digits printed, and the stated range covers the measured number.
By their numbers in this assay, from the lowest: compounds 3, 4, 2 and 1 (each within the scatter of the next, the first and the last beyond it).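

In this assay, for the compounds shown here, the exchange of 4-chlorophenoxy for 4-fluorophenoxy gives a number 7.8 percentage points lower from compound 1 to compound 4 (within the scatter) and so offers the first reading at this position, on the aromatic carbon para to a large group. Going by these compounds alone, for this one pair of halogens, the position shows no step beyond the scatter, whereas the only such step so far came from the change at the other aromatic ring. Nothing given here accounts for the size of this step, and the known difference in configuration between two of the earlier compounds does not bear on it.

As far as these compounds go, whether a nitrile, a trifluoromethyl or an amine at the same position would give a step beyond the scatter remains open. So does whether the same halogen exchange would give a similar step on the opposite configuration, that of compound 2.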